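The source may hold more compounds than are shown below. What is called first, only, known or untested is meant among the compounds shown, and "the series" means these compounds.

Of the compounds shown here, three built on one shared core have been tested in an ADME assay on HEK-293T cells (Homo sapiens) for inhibition, read by CCK-8 assay, with a stated time of 48 h, tested at 20 uM; on this read-out lower numbers stand for less inhibition of growth and higher numbers for more inhibition of growth at the one concentration tested. Compound 1 (`Cc1ccc(S(=O)(=O)Oc2ccccc2/C=C(\C#N)C(=O)Nc2nnc(Cc3cccc(F)c3)s2)cc1`) gives 9%, the only figure available in this series. Compound 2 (`N#C/C(=C\c1ccccc1OS(=O)(=O)c1ccc([N+](=O)[O-])cc1)C(=O)Nc1nnc(Cc2cccc(F)c2)s1`) has no single number and is recorded as "not toxic" (no number reported), so it cannot be placed numerically against compound 1. Compound 3 (`N#C/C(=C\c1ccccc1OS(=O)(=O)c1ccccc1[N+](=O)[O-])C(=O)Nc1nnc(Cc2cccc(F)c2)s1`) is the one further entry of this kind, also recorded as "not toxic" (no number reported).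

Compound 4 (`Cc1ccc(Cc2nnc(NC(=O)/C(C#N)=C/c3ccccc3OS(=O)(=O)c3ccc([N+](=O)[O-])cc3)s2)cc1`) has yet to be measured. It carries 4-methylphenyl in place of the 3-fluorophenyl of compound 2, on a saturated chain carbon bound to an aromatic carbon (4-methylphenyl in place of 3-fluorophenyl on a saturated chain carbon bound to an aromatic carbon). Among the compounds with values here, no measured pair shows the size of this change. In this assay, no step beyond the usual scatter is expected in either direction, an expectation that rests on compound 2 with its entry of "not toxic" (no number reported) and on compound 1 with 9%. Compound 4 is expected to give 10%, with an estimated range from 0% to 25%.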

Compound 4, percent growth inhibition at one concentration: 9%
Compound 4: middle estimate off by 1 percentage points, on the high side, and the stated range covers the measured number.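

Within the data shown here, compound 2 has no single number in this assay and compound 4 does, so no step between compound 2 and compound 4 can be read. The compounds shown leave open what going from 3-fluorobenzyl to 4-methylbenzyl does to growth inhibition. No further data bear on this result.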